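The source may report more compounds than this note shows. Statements on the series, on what has been measured and on what is new or still open speak of the compounds shown alone.

The measured compounds in a functional assay on MCF7 cells (Homo sapiens) for inhibition, read by sulforhodamine B assay; a higher number here means a weaker inhibitor, a lower number a stronger inhibitor:
compound 1 `COc1cccc(NC2=CC(=O)c3c(nc4n3[C@H]3OC[C@@H](O)[C@H]3OC4)C2=O)c1` gives 3830 nM.
compound 2 `O=C1C(NC2CC2)=CC(=O)c2c1nc1n2[C@H]2OC[C@@H](O)[C@H]2OC1` gives only a limit, > 16000 nM.
compound 3 `O=C1C(Nc2ccc(C(F)(F)F)cc2)=CC(=O)c2c1nc1n2[C@H]2OC[C@@H](O)[C@H]2OC1` gives only a limit, > 4000 nM.

Compound 3 thus stands at a limit and not at a number, the one named in the limit of > 4000 nM in this assay, at which 1 of the 3 values shown sits. Compound 4 `O=C1C(NCc2ccccc2)=CC(=O)c2c1nc1n2[C@H]2OC[C@@H](O)[C@H]2OC1` differs from compound 3 by benzyl in place of 4-(trifluoromethyl)phenyl on an amine nitrogen. Within the data shown here, the only measured step that ends at compound 3 through a change on the same nitrogen, a step that the two limits leave unreadable from compound 2 to compound 3, cannot be read. The step of an at least 4.1-fold higher number from compound 1 to compound 2 (0.62 log units; beyond the scatter) shows a weakening beyond the scatter, while an at least 1.0-fold higher number from compound 1 to compound 3 (0.01 log units; that floor lies within the scatter) stays within it. Because an at least 4.1-fold higher number from compound 1 to compound 2 (0.62 log units; beyond the scatter) points to weaker inhibition once the aromatic ring leaves the nitrogen, compound 4 is expected to stay weak, and a step that the limit leaves unreadable from compound 3 to compound 4 is estimated to be small or unreadable. Compound 4 is expected to give about 8000 nM, somewhere between 3000 nM and 25000 nM, most likely again as a limit.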

Compound 4, half-maximal inhibitory concentration: > 8000 nM
Compound 4 gave a limit, no number (the forecaster's own chance of this, stated with the estimate: 60%); the middle value lies on the limit itself.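

In this assay, benzyl in place of 3-methoxyphenyl on the amine nitrogen gives an at least 2.0-fold higher number from compound 1 to compound 4 (0.31 log units; beyond the scatter). A benzyl group on this nitrogen thus joins the cyclopropyl of compound 2 in not reaching the value of compound 1, so this change adds a second group that falls short of it. The steps among compound 2, compound 3 and compound 4 cannot be read, as all three values are limits. As far as these compounds go, it remains open how far compound 4 truly lies from compound 1. From the compounds shown here alone, it also remains open whether a phenethyl chain or a 3-methoxybenzyl group on this nitrogen would match compound 1.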